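From isopropyl to (trifluoromethyl)sulfanyl on the shared core

A few compounds are considered here, and "the series" means these few. Any claim that something is new, unique, unknown or untested is made for them only; others in the source may bear on it.

In a functional assay on the whole organism with Rattus norvegicus as the target (a lower number here means that less compound is needed, a higher number that more compound is needed for the effect), compound 1 (`CCCc1ccc2nc(N)sc2c1`) gives 6 mg/kg. Compound 2 (`CC(C)c1ccc2nc(N)sc2c1`) has only a limit, > 10 mg/kg. Compound 3 (`Nc1nc2ccc(SC(F)(F)F)cc2s1`) carries (trifluoromethyl)sulfanyl in place of isopropyl on an aromatic carbon. Within the data shown here, the one measured step bearing on this change, an at least 1.6-fold higher number from compound 1 to compound 2 (0.22 log units; that floor lies within the scatter), has a floor within the scatter and so fixes no size. The expectation therefore rests on compound 1 at 6 mg/kg, which points to a modest move towards a lower number. The expected move is an at least 2.0-fold lower number from compound 2 to compound 3 (0.30 log units; that floor lies within the scatter). For compound 3 the estimated value is 5 mg/kg, with an expected range of 1.5 mg/kg to 15 mg/kg.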

Compound 3, dose for half-maximal effect: 8 mg/kg
Beside the measured number, compound 3's estimate is 1.6-fold (0.20 log units) below it; measured number inside the range.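

In this assay, (trifluoromethyl)sulfanyl on the aromatic carbon is not separated from propyl, with a 1.3-fold higher number from compound 1 to compound 3 (0.12 log units; within the scatter). Replacing isopropyl gives an at least 1.2-fold lower number from compound 2 to compound 3 (0.09 log units; that floor lies within the scatter), which fixes no size for this change. Compound 2 is held only as a limit: the limit of > 10 mg/kg in this assay, at which 1 of the 3 values shown sits.

Still open, as far as these compounds go, is how far compound 2 actually lies from compound 3. Also open, from the compounds shown here alone, is whether a longer chain such as butyl, or an amine, at this position would separate from propyl in this assay.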